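Inverting one stereocentre of compound 2

The source may hold more compounds than are shown below. What is called first, only, known or untested is meant among the compounds shown, and "the series" means these compounds.

Compound 1 `C[C@H]1CN([C@@H](C)CO)C(=O)c2cccc(NC(=O)c3ccncc3)c2O[C@H]1CN(C)Cc1ccc(Oc2ccccc2)cc1`: < 1%
Compound 2 `C[C@@H]1CN([C@H](C)CO)C(=O)c2cccc(NC(=O)c3ccncc3)c2O[C@@H]1CN(C)Cc1ccc(Oc2ccccc2)cc1`: < 1%

Both entries come from an ADME assay on microsomes (Mus musculus) for metabolic stability, with a stated time of 1 h, tested at 1 uM (a lower number here means that less of the compound is left, a higher number that more of the compound is left), and neither is an exact number. Compound 1 gives < 1%, which is a limit of the assay. Compound 2 gives < 1%, which is also a limit. Compound 2 therefore stands at the bottom of the readable scale, and the pair shares (the limit of < 1% in this assay, at which 2 of the 2 values shown sit).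

The next compound, compound 3 `C[C@@H]1CN([C@H](C)CO)C(=O)c2cccc(NC(=O)c3ccncc3)c2O[C@H]1CN(C)Cc1ccc(Oc2ccccc2)cc1`, is a close relative of compound 2: the two compounds have the same atoms and bonds and differ only in configuration as drawn: 1 of 3 stereo elements differ; a stereocentre at a saturated ring carbon is drawn S in compound 2 and R in compound 3. Nothing is added or removed.

Among the compounds with values here, the only measured evidence is a step that the two limits leave unreadable from compound 1 to compound 2. That comparison rests on (the fact that compounds 1 and 2 differ only in the configuration as drawn), and all three stereocentres change in it, yet neither compound rises to a readable value. Its true size stays hidden, so it offers only weak guidance. Compound 3 changes just one of those centres, so a clear recovery seems unlikely.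

The expected outcome is a number no lower from compound 2 to compound 3 (the limit leaves the size open), with no change beyond the scatter. The estimated value for compound 3 is 1%, with an expected range from 0% to 6%.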

Compound 3, percent of the compound remaining: 1%
The estimate for compound 3 equals the measured number at the digits printed; low and high end bracket the measured number.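

In this assay, within the data shown here, compound 3 gives 1%, the first readable number. Compound 2 gives < 1%, which is a limit of the assay. The data show a number no lower from compound 2 to compound 3 (the limit leaves the size open), so no size can be given for turning this saturated ring carbon from S to R, yet the change leaves compound 3 at the very bottom of the readable scale, and the comparison with compound 2 is a clean one: the fact that compounds 2 and 3 differ only in the configuration as drawn.

As far as these compounds go, all three compounds share the same atoms and bonds, so it remains open whether a change in structure rather than in configuration, such as a carboxylic acid or a longer chain on the shared core, would leave more of the compound in this assay. With a number no lower from compound 1 to compound 3 (the limit leaves the size open) as the only further step, it is also open whether any other arrangement of the stereocentres, beyond the three shown here, would give a number clearly higher on this scale.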